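Pyrimidine hydrazide series: aryl swap at the core position

The source may hold more compounds than are shown below. What is called first, only, known or untested is meant among the compounds shown, and "the series" means these compounds.

Measured compounds:
compound 1 `CCOC(=O)c1cnc(C)nc1NN1C(=O)C=C(C)C1=O` — 16000 nM
compound 2 `CCOC(=O)c1cnc(C(C)(C)C)nc1NN1C(=O)C=C(C)C1=O` — 1000 nM
compound 3 `CCOC(=O)c1cnc(-c2ccc(C(F)(F)F)cc2)nc1NN1C(=O)C=C(C)C1=O` — 400 nM

In a functional assay on Jurkat cells for inhibition of nuclear factor NF-kappa-B complex (Homo sapiens) (a higher number here means a weaker inhibitor, a lower number a stronger inhibitor), compound 3 stands with the lowest number of the three measured compounds. The steps to it are a 40-fold lower number from compound 1 to compound 3 (1.60 log units; beyond the scatter) and a 2.5-fold lower number from compound 2 to compound 3 (0.40 log units; beyond the scatter); the remaining measured step is a 16-fold lower number from compound 1 to compound 2 (1.20 log units; beyond the scatter). Both large steps replace a methyl on the core with a bulkier group, and the modest step moves from tert-butyl to a substituted phenyl.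

Compound 4 `CCOC(=O)c1cnc(-c2cccc(Br)c2)nc1NN1C(=O)C=C(C)C1=O` is not yet measured. The change from compound 3 is 3-bromophenyl in place of 4-(trifluoromethyl)phenyl on an aromatic carbon. Among the measured compounds shown here, no measured step exchanges one substituted phenyl for another; the only step that bears on it is the modest one from compound 2 to compound 3, which shows that a substituted phenyl at this position gives the lowest number seen so far. Since compound 4 keeps a substituted phenyl there, the expected change is small, a 1.5-fold higher number from compound 3 to compound 4 (0.18 log units; within the scatter), with no firm direction beyond the scatter. For compound 4 the expected value in this assay is 600 nM, in the range 200 nM to 2000 nM.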

Compound 4, half-maximal inhibitory concentration: 700 nM
For compound 4 the middle estimate is 1.2-fold (0.07 log units) below the measured one; the range from low to high includes it.
By their numbers in this assay, from the lowest: compounds 3, 4 and 2 (each within the scatter of the next, the first and the last beyond it); then compound 1.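

Exchanging one substituted phenyl for another at this position gives a 1.8-fold higher number from compound 3 to compound 4 (0.24 log units; within the scatter) in this assay and so does not separate 3-bromophenyl from 4-(trifluoromethyl)phenyl. The advantage of a substituted phenyl over tert-butyl is also less secure than compound 3 alone suggested, as 3-bromophenyl in place of tert-butyl gives a 1.4-fold lower number from compound 2 to compound 4 (0.15 log units; within the scatter) while the gain over methyl remains clear, with a 23-fold lower number from compound 1 to compound 4 (1.36 log units; beyond the scatter) as the step. Nothing available explains these steps.

From the compounds shown here alone, the effect of moving a substituent around the phenyl remains open, as compound 3 and compound 4 differ in both the substituent and its location. Also open, going by these compounds, is how an unsubstituted phenyl, or a phenyl carrying an amine or a carboxylic acid, would read at this position.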